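This account rests on a few compounds, and the source may have more. Where it says the series, first, only, none or still open, it means among the compounds named here.

Among the measured compounds shown here, compound 2 `COc1cc(C(=O)NC2(C(=O)N[C@H](C)c3ccc(-n4nc(Cl)c5ccccc54)cc3F)CC2)on1` is one of two compounds so far measured in an in vivo ADME assay on the whole organism (strain Mongrel) for pharmacokinetics, with Canis familiaris (Canis lupus familiaris) as the target; on this read-out lower numbers stand for slow clearance and higher numbers for fast clearance; in this assay compound 2 gives 1.3 mL/min/kg. For the measured compounds named here, its only measured neighbour, compound 1 `C[C@@H](NC(=O)C1(NC(=O)c2cncc(Cl)c2)CC1)c1ccc(-n2nc(Cl)c3ccccc32)cc1F`, gives 3.1 mL/min/kg in this assay, so compound 2 holds the lower of the two numbers, and the step of a 2.4-fold lower number from compound 1 to compound 2 (0.38 log units; beyond the scatter) comes from exchanging one ring for another on a carbonyl carbon. Compound 3 `Cc1nnsc1C(=O)NC1(C(=O)N[C@H](C)c2ccc(-n3nc(Cl)c4ccccc43)cc2F)CC1` differs from compound 2 at that same place: 4-methyl-1,2,3-thiadiazol-5-yl in place of 3-methoxy-1,2-oxazol-5-yl on a carbonyl carbon. Going by the values given here, only one measured step bears on such a swap of the ring on that carbonyl, namely a 2.4-fold lower number from compound 1 to compound 2 (0.38 log units; beyond the scatter), and it shows that a ring exchange there can move the number modestly. That single step does not show which way a third ring would move it, so for compound 3 the expectation is a step of a 1.4-fold higher number from compound 2 to compound 3 (0.14 log units; within the scatter), within the scatter. Compound 3 is therefore estimated at 1.8 mL/min/kg, with a range from 0.8 mL/min/kg to 4 mL/min/kg.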

Compound 3, clearance: 9.6 mL/min/kg
Compound 3: middle estimate off by 5.3-fold (0.73 log units), on the low side, outside the stated range (above it).
By their numbers in this assay, from the lowest: compound 2; then compound 1; then compound 3.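

In this assay the change to 4-methyl-1,2,3-thiadiazol-5-yl gives a 7.4-fold higher number from compound 2 to compound 3 (0.87 log units; beyond the scatter) and also gives a 3.1-fold higher number from compound 1 to compound 3 (0.49 log units; beyond the scatter) so a ring exchange on this carbonyl carbon can raise the number as well as lower it. The two five-membered aromatic rings, 3-methoxy-1,2-oxazol-5-yl and 4-methyl-1,2,3-thiadiazol-5-yl, now stand at opposite ends of the series, with 5-chloropyridin-3-yl in the middle, so having a five-membered aromatic ring here does not by itself keep the number low. Nothing measured here accounts for this difference between the rings.

The compounds shown do not separate the part played by the methyl group from that of the thiadiazole ring itself. They also leave open how a ring carrying an amine or a carboxylic acid would behave on this carbonyl carbon.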